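The compounds below may be only part of what the source reports. "The series", "measured", "known", "first", "only" and "open" are said of these compounds alone.

Of the compounds shown here, three that share a core have been measured in a functional assay on SK-OV-3 cells (Homo sapiens) for cytotoxicity, read by MTT assay, with a stated time of 48 h; on this read-out lower numbers stand for stronger inhibition and higher numbers for weaker inhibition. Compound 1 `O=C(/C=C/c1ccc2c(c1)B(O)OC2)c1ccco1` carries a furan-2-yl on the carbonyl carbon and gives 20700 nM. Compound 2 `O=C(/C=C/c1ccc2c(c1)B(O)OC2)c1cccs1`, with thiophen-2-yl on the carbonyl carbon, gives 10400 nM, the change being a 2.0-fold lower number from compound 1 to compound 2 (0.30 log units; within the scatter). Compound 3 `O=C(/C=C/c1ccc2c(c1)B(O)OC2)c1ccc(Cl)cc1` carries 4-chlorophenyl on the carbonyl carbon and gives 3700 nM; the steps leading to it are a 5.6-fold lower number from compound 1 to compound 3 (0.75 log units; beyond the scatter) and a 2.8-fold lower number from compound 2 to compound 3 (0.45 log units; beyond the scatter). Compound 3 thus stands lowest of the three measured compounds, with compound 2 nearest to it and compound 1 furthest away.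

Compound 4 `CCc1ccc(C(=O)/C=C/c2ccc3c(c2)B(O)OC3)cc1` has not yet been measured. It differs from compound 3 by ethyl in place of chloro on an aromatic carbon. Going by the values given here, none of the measured steps bears directly on this change: each of them exchanges the whole ring attached to the carbonyl carbon, whereas here that ring is kept and only the group on one of its aromatic carbons is exchanged. The measured steps show that the series as a whole moves within a modest span, and an exchange of chloro for ethyl on that ring gives no ground to expect a large departure. Compound 4 is therefore expected to stay close to compound 3, with a 1.4-fold higher number from compound 3 to compound 4 (0.13 log units; within the scatter) the estimated step and no clear direction. The estimate for compound 4 in this assay is 5000 nM, in the range 1500 nM to 16000 nM.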

Compound 4, half-maximal inhibitory concentration: 4400 nM
The estimate for compound 4 lay 1.1-fold (0.06 log units) above the measured number, within the range that was stated.
By their numbers in this assay, from the lowest: compounds 3 and 4 (each within the scatter of the next); then compounds 2 and 1 (each within the scatter of the next).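

In this assay, the exchange of chloro for ethyl on an aromatic carbon, para to a large group, gives a 1.2-fold higher number from compound 3 to compound 4 (0.08 log units; within the scatter), so this read-out does not separate the two groups at this position. Going by these compounds alone, the earlier steps each exchanged the whole ring on the carbonyl carbon, whereas this one keeps the ring and gives the first reading of a group on it: here, a halogen and an alkyl group give numbers within the scatter of each other. No data are at hand that would account for this result.

From the compounds shown here alone, two groups without a hydrogen-bond donor or acceptor say little about the position as a whole, so it remains open whether an amine, a carboxylic acid, a hydroxyl or a longer chain such as butyl at the same place would leave the number where it is or move it beyond the scatter. The compounds shown also leave open whether chloro and ethyl would stay as close together on another carbon of that ring, or on the thiophen-2-yl and furan-2-yl rings of the other two compounds.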